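A Substituent Swap at the Aromatic Nitrogen Arm

The source may report more compounds than this note shows. Statements on the series, on what has been measured and on what is new or still open speak of the compounds shown alone.

Compound 1 `C=CCn1cc(COc2cc(O)c3c(c2)O[C@H](c2ccc(OC)c(O)c2)CC3=O)nn1`, compound 2 `COc1ccc([C@@H]2CC(=O)c3c(O)cc(OCc4cn(C)nn4)cc3O2)cc1O` and compound 3 `COc1ccc([C@@H]2CC(=O)c3c(O)cc(OCc4cn(Cc5ccc(Cl)cc5)nn4)cc3O2)cc1O` share one core and differ only in the group on a saturated chain carbon bound to an aromatic nitrogen. In a functional assay on RAW264.7 cells (Mus musculus) for inhibition, read by Griess assay, with stated times of 2 h and 24 h (a lower number here means a stronger inhibitor, a higher number a weaker inhibitor), compound 1 gives 13800 nM, compound 2 gives 15200 nM and compound 3 gives 17800 nM. Compound 3 carries the highest of the three numbers, but the steps of a 1.3-fold higher number from compound 1 to compound 3 (0.11 log units; within the scatter) and a 1.2-fold higher number from compound 2 to compound 3 (0.07 log units; within the scatter), like a 1.1-fold higher number from compound 1 to compound 2 (0.04 log units; within the scatter), all sit within the scatter, so none of the three is told apart from the others.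

Compound 4 `COc1ccc([C@@H]2CC(=O)c3c(O)cc(OCc4cn(Cc5cccc(C(F)(F)F)c5)nn4)cc3O2)cc1O` is reached from compound 3 by the change (3-(trifluoromethyl)phenyl in place of 4-chlorophenyl on a saturated chain carbon bound to an aromatic nitrogen). The measured steps that bear on this change are those at the same place, a 1.3-fold higher number from compound 1 to compound 3 (0.11 log units; within the scatter) and a 1.2-fold higher number from compound 2 to compound 3 (0.07 log units; within the scatter); both are small, and the group at this position has so far shown no effect beyond the scatter in this assay. No step beyond the scatter is therefore expected, in either direction, from compound 3 to compound 4. Compound 4 is estimated at 17000 nM, with an expected range from 8000 nM to 36000 nM, which means an expected step of a 1.0-fold lower number from compound 3 to compound 4 (0.02 log units; within the scatter).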

Compound 4, half-maximal inhibitory concentration: 19900 nM
The estimate for compound 4 lay 1.2-fold (0.07 log units) below the measured number; measured number inside the range.
By their numbers in this assay, from the lowest: compounds 1, 2, 3 and 4 (each within the scatter of the next).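

In this assay, replacing the 4-chlorophenyl with 3-(trifluoromethyl)phenyl on a saturated chain carbon bound to an aromatic nitrogen gives a 1.1-fold higher number from compound 3 to compound 4 (0.05 log units; within the scatter), so exchanging one substituted aromatic ring for another, with a different substituent at a different ring position, leaves the compounds untold apart. Set against the two groups without a ring, the new group gives a 1.3-fold higher number from compound 2 to compound 4 (0.12 log units; within the scatter) and a 1.4-fold higher number from compound 1 to compound 4 (0.16 log units; within the scatter), which extends the flat picture to four groups: hydrogen, vinyl, 4-chlorophenyl and 3-(trifluoromethyl)phenyl, with no compound among the four going against it. No further evidence is at hand that would explain this lack of response at the position.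

The compounds shown carry only hydrocarbon or halogen-bearing aryl groups at this place, so they leave open whether an amine, a carboxylic acid or a longer chain there would move the number beyond the scatter. They also leave open how the remaining parts of the shared core contribute, since those parts do not vary among these four compounds.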